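Cutting the urea side chain down to methyl

The source may hold more compounds than are shown below. What is called first, only, known or untested is meant among the compounds shown, and "the series" means these compounds.

In a functional assay on U-87MG ATCC cells for cytotoxicity against U-87 MG (Homo sapiens), read by MTT assay, with a stated time of 72 h (on this read-out higher numbers stand for weaker inhibition and lower numbers for stronger inhibition), compound 1 `COc1ncc(-c2ccc3nc(NC(=O)NCC(=O)N4CCCCC4)nn3c2)cc1NS(=O)(=O)c1ccc(F)cc1` gives 740 nM and compound 2 `COc1ncc(-c2ccc3nc(NC(=O)NCCN(C)C)nn3c2)cc1NS(=O)(=O)c1ccc(F)cc1` gives 980 nM so that compound 2 stands level with compound 1 within the scatter.

Compound 3 `CNC(=O)Nc1nc2ccc(-c3cnc(OC)c(NS(=O)(=O)c4ccc(F)cc4)c3)cn2n1` carries hydrogen in place of (dimethylamino)methyl on a saturated chain carbon bound to an amide-type nitrogen and the same difference reads as 2-(dimethylamino)ethyl to methyl.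

Among the measured compounds shown here, only one measured step bears on this place. It is a 1.3-fold higher number from compound 1 to compound 2 (0.12 log units; within the scatter) and it puts (dimethylamino)methyl in place of (piperidin-1-yl)carbonyl on that same carbon. That exchange stayed within the scatter, but it replaced one group with another, whereas compound 3 has only hydrogen there. For the measured compounds named here, no measured compound shows that removal, so the evidence is thin and the range is kept wide.

In this assay the expected move is a 1.4-fold lower number from compound 2 to compound 3 (0.15 log units; within the scatter) and no shift beyond the scatter is expected. The estimate for compound 3 is 700 nM with an expected range of 250 nM to 2000 nM in this read-out.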

Compound 3, half-maximal inhibitory concentration: 640 nM
Beside the measured number, compound 3's estimate is 1.1-fold (0.04 log units) above it; the measured number falls inside the stated range.
By their numbers in this assay, from the lowest: compounds 3, 1 and 2 (each within the scatter of the next).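

In this assay the shortened compound gives a 1.5-fold lower number from compound 2 to compound 3 (0.19 log units; within the scatter) and a 1.2-fold lower number from compound 1 to compound 3 (0.06 log units; within the scatter). All three compounds stand level. The earlier step only exchanged one group for another on the saturated chain carbon bound to an amide-type nitrogen, whereas compound 3 has hydrogen there and keeps neither the (dimethylamino)methyl nor the (piperidin-1-yl)carbonyl group. Across these three compounds, then, neither group is needed to hold the number at this level, and no accompanying measurement indicates what lies behind that result.

The compounds shown leave open whether a carboxylic acid or a longer chain ending in a primary amine at this place would move the number beyond the scatter in either direction. Also open, as far as these compounds go, is whether the methyl itself can be exchanged, for instance for ethyl or cyclopropyl, without leaving that scatter.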